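A few compounds are considered here, and "the series" means these few. Any claim that something is new, unique, unknown or untested is made for them only; others in the source may bear on it.

Measured so far:
Compound 1, `CCCCNc1nnc(SCC(=O)N(Cc2cccc([N+](=O)[O-])c2)c2ccc(F)cc2)s1`: in an assay on isolated protein for inhibition of Amine oxidase [flavin-containing] B (Homo sapiens), read by fluorescence and Amplex Red, with a stated time of 30 min, tested at 100 uM (a lower number here means a weaker effect, a higher number a stronger effect of the compound at the concentration tested), compound 1 gives 34.3%.
Compound 2, `CCCNc1nnc(SCC(=O)N(Cc2cccc([N+](=O)[O-])c2)c2ccc(F)cc2)s1`: in this assay compound 2 gives 26.8%.

Compound 2 holds the lower of the two numbers in this assay, yet the gap to compound 1, a step of a number 7.5 percentage points lower from compound 1 to compound 2 (within the scatter), lies within the scatter, so the two compounds cannot be ordered on this evidence.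

Compound 3, `CC(C)CNc1nnc(SCC(=O)N(Cc2cccc([N+](=O)[O-])c2)c2ccc(F)cc2)s1`, has not been measured. It differs from compound 2 by methyl in place of hydrogen on a saturated chain carbon bound to two saturated chain carbons. Among the compounds with values here, the only measured step that bears on it is the one from compound 1 to compound 2, where a methyl was removed from the chain end and the number moved by a number 7.5 percentage points lower from compound 1 to compound 2 (within the scatter), within the scatter. Restoring a methyl, now on the branched position, is therefore expected to produce no step beyond the scatter, with at most a slight rise in line with that earlier step.

Compound 3 is thus estimated to reach 31% in this assay, with a range from 15% to 47%, meaning an expected step of a number 4.2 percentage points higher from compound 2 to compound 3 (within the scatter).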

Compound 3, a percentage reported as inhibition, at one concentration (the size of the read-out at that concentration, not a potency): 24.2%
The estimate for compound 3 lay 6.8 percentage points above the measured number; the range from low to high includes it.
By their numbers in this assay, from the lowest: compounds 3, 2 and 1 (each within the scatter of the next, the first and the last beyond it).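

In this assay, methyl in place of hydrogen on a saturated chain carbon bound to two saturated chain carbons, the change from propylamino to isobutylamino, gives a number 2.6 percentage points lower from compound 2 to compound 3 (within the scatter), so this branch does not separate the two compounds. The comparison with the unbranched chain of compound 1 reads differently: isopropyl in place of propyl on a saturated chain carbon bound to a nitrogen on an aromatic ring gives a number 10.1 percentage points lower from compound 1 to compound 3 (beyond the scatter), a modest step and the first in this set to pass beyond the scatter, which suggests that the branched and unbranched forms of the chain may not be equivalent here, although compound 2 stands within the scatter of both. No measurement available here accounts for this difference.

What the compounds shown leave open is whether a longer chain, a cyclohexyl group or a hydroxyl on the chain would carry the number further in either direction than these small steps do. On these data alone, each value also comes from a single tested concentration, so the values show only the size of the effect at that concentration, and whether the modest step between compound 1 and compound 3 would hold up as a stronger or weaker effect at other concentrations remains unknown.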